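Terminal amine on the propoxy chain: compound 4

A few compounds are considered here, and "the series" means these few. Any claim that something is new, unique, unknown or untested is made for them only; others in the source may bear on it.

Measured compounds:
compound 1 `COc1cc2c(Oc3ccc(NC(=O)c4nn(-c5ccccc5)c(=O)c5ccccc45)cc3F)ccnc2cc1OCCCN1CCCC1` — 1130 nM
compound 2 `COc1cc2c(Oc3ccc(NC(=O)c4nn(-c5ccccc5)c(=O)c5ccccc45)cc3F)ccnc2cc1OCCCN1CCN(C)CC1` — 1580 nM
compound 3 `COc1cc2c(Oc3ccc(NC(=O)c4nn(-c5ccccc5Br)c(=O)c5ccccc45)cc3F)ccnc2cc1OCCCN1CCN(C)CC1` — 1680 nM

All three numbers come from a functional assay on MDA-MB-231 cells (Homo sapiens) for cytotoxicity, read by MTT assay, with a stated time of 72 h; on this read-out lower numbers stand for stronger inhibition and higher numbers for weaker inhibition. Compound 2 holds the second highest of the three numbers; its nearest neighbour is compound 3 and its furthest is compound 1, and both separations are within the scatter, so on the present data the three compounds cannot be ordered.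

The step to the unmeasured compound 4 `COc1cc2c(Oc3ccc(NC(=O)c4nn(-c5ccccc5)c(=O)c5ccccc45)cc3F)ccnc2cc1OCCCN1CCCCC1` is piperidin-1-yl in place of 4-methylpiperazin-1-yl on a saturated chain carbon, three bonds along the chain from an oxygen on an aromatic ring. For the measured compounds named here, only one measured step touches the same place: a 1.4-fold higher number from compound 1 to compound 2 (0.15 log units; within the scatter), where a five-membered saturated amine ring with one hetero atom was exchanged for the 4-methylpiperazin-1-yl group without a change beyond the scatter. The other step, a 1.1-fold higher number from compound 2 to compound 3 (0.03 log units; within the scatter), sits elsewhere and likewise stayed within the scatter. The exchange to piperidin-1-yl is of the same kind as the first of these, so in this assay no step beyond the scatter is expected, in either direction.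

For compound 4 the expected value in this assay is 1300 nM, with a range of 600 nM to 2800 nM, which corresponds to an expected step of a 1.2-fold lower number from compound 2 to compound 4 (0.08 log units; within the scatter).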

Compound 4, half-maximal inhibitory concentration: 1880 nM
For compound 4 the middle estimate is 1.4-fold (0.16 log units) below the measured one; the measured number falls inside the stated range.
By their numbers in this assay, from the lowest: compounds 1, 2, 3 and 4 (each within the scatter of the next).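

In this assay the terminal amine now covers three saturated rings, and the exchange of 4-methylpiperazin-1-yl for piperidin-1-yl gives a 1.2-fold higher number from compound 2 to compound 4 (0.08 log units; within the scatter), so dropping from two ring nitrogens to one does not move the number beyond the scatter. The ring-size exchange, pyrrolidin-1-yl to piperidin-1-yl, gives a 1.7-fold higher number from compound 1 to compound 4 (0.22 log units; within the scatter), which is the largest step printed at this place and still does not separate the two compounds. Across compounds 1, 2 and 4 this position therefore tolerates all three amine rings in this cell assay without any measurable separation, although no data on why the read-out stays so flat are available.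

The compounds shown leave open whether any terminal group outside these saturated amine rings, such as morpholin-4-yl, dimethylamino or a carboxylic acid, or a shorter or longer chain in place of the propyl linker, would produce a step beyond the scatter. They also leave open whether bromo on the aromatic ring behaves the same way with piperidin-1-yl or pyrrolidin-1-yl as the terminal amine.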